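This account rests on a few compounds, and the source may have more. Where it says the series, first, only, none or still open, it means among the compounds named here.

Measured so far in a functional assay (Cavia porcellus) with sulfonylurea receptors; K-ATP channels (Homo sapiens) as the target; a higher number here means a weaker inhibitor, a lower number a stronger inhibitor:
compound 1 `CC(O)(C(=O)Nc1ccc(S(=O)(=O)c2ccccc2C#N)cc1)C(F)(F)F` gives 1100 nM;
compound 2 `COc1cccc(S(=O)(=O)c2ccc(NC(=O)C(C)(O)C(F)(F)F)cc2)c1` gives 16000 nM;
compound 3 `Cc1cccc(S(=O)(=O)c2ccc(NC(=O)C(C)(O)C(F)(F)F)cc2)c1` gives 2200 nM.

Compound 3 stands second highest of the three numbers: its nearest neighbour is compound 1, with a 2.0-fold higher number from compound 1 to compound 3 (0.30 log units; within the scatter), and its furthest is compound 2, with a 7.3-fold lower number from compound 2 to compound 3 (0.86 log units; beyond the scatter). The step to compound 4 `CC(O)(C(=O)Nc1ccc(S(=O)(=O)c2cnccn2)cc1)C(F)(F)F` is pyrazin-2-yl in place of 3-methylphenyl on a sulfonyl sulfur. Among the compounds with values here, no measured step exchanges the ring on the sulfonyl sulfur for one with hetero atoms; the steps that bear on it are the other exchanges at that sulfur, a 15-fold higher number from compound 1 to compound 2 (1.16 log units; beyond the scatter) and a 2.0-fold higher number from compound 1 to compound 3 (0.30 log units; within the scatter), which show that this position moves the numbers in this assay by anything from within the scatter to a large amount. A modest step, more likely upward than downward, is therefore expected, giving a 1.6-fold higher number from compound 3 to compound 4 (0.20 log units; within the scatter). Compound 4 is estimated at 3500 nM, with a range from 800 nM to 15000 nM.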

Compound 4, half-maximal inhibitory concentration: 12000 nM
Compound 4: the middle estimate sits 3.4-fold (0.54 log units) below what was measured; measured number inside the range.
By their numbers in this assay, from the lowest: compounds 1 and 3 (each within the scatter of the next); then compounds 4 and 2 (each within the scatter of the next).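

In this assay pyrazin-2-yl, the only ring with hetero atoms shown on the sulfonyl sulfur, gives a 5.5-fold higher number from compound 3 to compound 4 (0.74 log units; beyond the scatter) and an 11-fold higher number from compound 1 to compound 4 (1.04 log units; beyond the scatter) so it is a weaker inhibitor than either of those compounds. Against 3-methoxyphenyl it gives a 1.3-fold lower number from compound 2 to compound 4 (0.12 log units; within the scatter) and thus no readable difference, so compound 2 goes against any rule that a carbon-only ring there outperforms this one. Nothing available explains these steps. As far as these compounds go, whether a pyridinyl ring would follow pyrazin-2-yl or the carbon-only rings stays open, as does the effect of an amine on the ring.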